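The source may hold more compounds than are shown below. What is called first, only, known or untested is meant among the compounds shown, and "the series" means these compounds.

In a physicochemical assay for solubility (a higher number here means a more soluble compound, a lower number a less soluble compound), compound 1 `C[C@@H]1CN(c2c(C#N)c(C(F)(F)F)nn2-c2ccc(S(C)(=O)=O)cn2)[C@H](C)CO1` gives > 200 ug/mL, which is a limit of the assay and not a number. Compound 2 `CS(=O)(=O)c1ccc(-n2nc(C(F)(F)F)c(C#N)c2NC2CCCC2)nc1` offers no reading to build on, as its entry is "not determined" (no result reported). Among the measured compounds shown here, its place on the scale is therefore unknown, and the only measured compound nearby gives a limit. Compound 3 `CC(C)(C)CNc1c(C#N)c(C(F)(F)F)nn1-c1ccc(S(C)(=O)=O)cn1` differs from compound 2 in one place: neopentyl in place of cyclopentyl on a nitrogen on an aromatic ring. Neopentyl stands in place of cyclopentyl on a nitrogen on an aromatic ring, so cyclopentylamino becomes neopentylamino, a group with no ring. For the measured compounds named here, no measured step of this kind is available as a guide. In this assay, this swap is expected to cause no step beyond the usual scatter, although without a number for compound 2 that expectation cannot be checked directly. For compound 3, the estimated solubility is 50 ug/mL, with an expected range from 10 ug/mL to 200 ug/mL.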

Compound 3, solubility: < 25 ug/mL
Compound 3 ended at the assay's limit; the forecaster's own chance of this, stated with the estimate: 20%; at least 2.0-fold (0.30 log units) between middle value and limit.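

Among the compounds shown here, replacing the ring-bearing group of compound 1 with the open-chain neopentylamino group, on an aromatic carbon, gives the first readable step at this position in this assay: an at least 8.0-fold lower number from compound 1 to compound 3 (0.90 log units; beyond the scatter). The reading for compound 3 is a limit of the assay and not a number: the limit of < 25 ug/mL in this assay, at which 1 of the 3 values shown sits. The reading for compound 1 is also a limit of the assay and not a number: the limit of > 200 ug/mL in this assay, at which 1 of the 3 values shown sits.

On these data alone, the step from compound 2 to compound 3 cannot be read, as compound 2 has no result, so the effect of going from cyclopentylamino to neopentylamino remains unknown. The compounds shown also leave open how a chain ending in a hydroxyl group or a carboxylic acid, placed on this nitrogen, would read in this assay.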